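The source may report more compounds than this note shows. Statements on the series, on what has been measured and on what is new or still open speak of the compounds shown alone.

The series shares one core, seen in compound 1 `CCOC(=O)c1c(-c2cc(F)cc(OC)c2)[nH]c2cc(OC)ccc2c1=O`, compound 2 `CCOC(=O)c1c(-c2cccc(OC)c2)[nH]c2cc(OC)ccc2c1=O` and compound 3 `CCOC(=O)c1c(-c2cccc(Oc3ccccc3)c2)[nH]c2cc(OC)ccc2c1=O`. In an ADME assay on BJ cells (Homo sapiens) for cytotoxicity, read by luminescence, with a stated time of 72 h (on this read-out higher numbers stand for an effect only at larger amounts of compound and lower numbers for an effect already at smaller amounts), compound 1 reaches only the limit of the assay, > 21500 nM. In this assay compound 2 likewise gives only a limit, > 21500 nM. In this assay compound 3 also gives only a limit, > 21500 nM. The step that the two limits leave unreadable from compound 1 to compound 2, hydrogen in place of fluoro on an aromatic carbon, and the step that the two limits leave unreadable from compound 2 to compound 3, phenyl in place of methyl on an oxygen on an aromatic ring, both run between two limits and so cannot be sized; every value shown sits at the limit of > 21500 nM in this assay, at which 3 of the 3 values shown sit. Compound 4 `CCOC(=O)c1c(-c2cccc(NC(C)=O)c2)[nH]c2cc(OC)ccc2c1=O` differs from compound 3 by acetamido in place of phenoxy on an aromatic carbon. Within the data shown here, no measured step bears on this change with a readable size; the only guide is the limit of > 21500 nM in this assay, at which 3 of the 3 values shown sit, which none of the measured compounds left. One therefore expects no step beyond the scatter, a step that the limit leaves unreadable from compound 3 to compound 4, and for compound 4 estimates 30000 nM within 15000 nM to 60000 nM in this assay, most likely reported once more only as a limit.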

Compound 4, half-maximal effective concentration: > 21500 nM
Compound 4: a limit, no number (the forecaster's own chance of this, stated with the estimate: 85%); the middle value does not contradict the limit.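

In this assay compound 4 also gives only a limit, > 21500 nM, so the steps to it from compound 2 and from compound 3 cannot be read. The compounds shown leave open at what concentration any of them would show an effect in this assay: the limit of > 21500 nM in this assay, at which 4 of the 4 values shown sit.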